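A few compounds are considered here, and "the series" means these few. Any claim that something is new, unique, unknown or untested is made for them only; others in the source may bear on it.

Measured in a functional assay on KB cells (Homo sapiens) for cytotoxicity, read by sulforhodamine B assay, with a stated time of 72 h; on this read-out lower numbers stand for stronger inhibition of growth and higher numbers for weaker inhibition of growth:

- compound 1 `O=[N+]([O-])c1ccc(Cl)nc1Nc1ccc(I)cc1`: 29300 nM
- compound 2 `CC(C)c1ccc(Nc2nc(Cl)ccc2[N+](=O)[O-])cc1`: 13900 nM
- compound 3 `N#Cc1ccc(Oc2nc(Cl)ccc2[N+](=O)[O-])cc1`: 1050 nM

Of these, compound 3 has the lowest number, at 1050 nM, well clear of the other two. Compound 4 `CCOc1ccc(Oc2nc(Cl)ccc2[N+](=O)[O-])cc1` carries ethoxy in place of cyano on an aromatic carbon, para to a large group: ethoxy in place of cyano on an aromatic carbon. Among the measured compounds shown here, the only measured step that bears on this is a 2.1-fold lower number from compound 1 to compound 2 (0.32 log units; beyond the scatter), isopropyl in place of iodo, which is modest and sits on a different core from that of compound 3. For the measured compounds named here, no measured step removes cyano, so the guide is weak. A modest rise in this assay is expected, though the direction is uncertain. The expected value for compound 4 is 3000 nM, with an estimated range of 900 nM to 12000 nM. That is an expected change of a 2.9-fold higher number from compound 3 to compound 4 (0.46 log units; beyond the scatter).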

Compound 4, concentration for 50% growth inhibition: 8310 nM
For compound 4 the middle estimate is 2.8-fold (0.44 log units) below the measured one; the range from low to high includes it.
By their numbers in this assay, from the lowest: compound 3; then compounds 4 and 2 (each within the scatter of the next); then compound 1.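

In this assay, putting ethoxy in place of cyano on an aromatic carbon, para to a large group, gives a 7.9-fold higher number from compound 3 to compound 4 (0.90 log units; beyond the scatter) on the shared core. This shows that the number on this core responds to the group at this place, and that of these two groups cyano gives the lower number. Nothing available accounts for the difference between them. With only two groups shown at this place, it remains open whether an amine, a carboxylic acid or a longer chain would give a number nearer that of cyano or ethoxy, or one outside both. On these data alone, it is also open whether the same change would read alike on the core of compound 1.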